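The source may hold more compounds than are shown below. What is called first, only, known or untested is meant among the compounds shown, and "the series" means these compounds.

Compound 1 `C=C(Br)C(=O)Nc1ccc(/C=C/C(=O)c2ccc(OCC)cc2)cc1` is the strongest of the three measured compounds in a functional assay on L1210 cells (Mus musculus) for antiproliferative activity, with a stated time of 48 h (a higher number here means a weaker inhibitor, a lower number a stronger inhibitor), where compound 1 gives 240 nM. Compound 2 `C=C(Br)C(=O)Nc1ccc(C(=O)/C=C/c2ccccc2)cc1` shares the bromoacrylamide end of compound 1 but is built on a different core; how the two cores differ is not broken down here. In this assay compound 2 gives 880 nM, which places it between the other two. Compound 3 `CCOc1ccc(C(=O)/C=C/c2ccc(N)cc2)cc1` is the analogue of compound 1 in which the amide has been stripped back to a free amine, and in this assay compound 3 gives 21000 nM. The structural change from compound 1 to compound 3 is hydrogen in place of (1-bromoethenyl)carbonyl on a nitrogen on an aromatic ring, and the step it made was an 88-fold higher number from compound 1 to compound 3 (1.94 log units; beyond the scatter).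

Compound 4 `Nc1ccc(C(=O)/C=C/c2ccccc2)cc1` has not yet been measured. It stands to compound 2 exactly as compound 3 stands to compound 1: the change is hydrogen in place of (1-bromoethenyl)carbonyl on a nitrogen on an aromatic ring, the same change at the same kind of place. Among the measured compounds shown here, since the single measured example of this change was a large loss, compound 4 is expected to fall in the same direction, with an estimated step of a 68-fold higher number from compound 2 to compound 4 (1.83 log units; beyond the scatter) in this assay, resting on the step from compound 1 to compound 3 of an 88-fold higher number from compound 1 to compound 3 (1.94 log units; beyond the scatter). On that basis compound 4 is estimated to give about 60000 nM in this assay, with a plausible range from 15000 nM to 250000 nM.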

Compound 4, half-maximal inhibitory concentration: 14000 nM
The estimate for compound 4 lay 4.3-fold (0.63 log units) above the measured number, and the stated range ends above it.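

In this assay, the change went the same way on the second core, with a 16-fold higher number from compound 2 to compound 4 (1.20 log units; beyond the scatter), so taking the (1-bromoethenyl)carbonyl group off the nitrogen and leaving hydrogen brought a large loss on both cores. The direction of the step carried over from one core to the other, but its size did not: the same change on two cores in this assay, an 88-fold higher number (1.94 log units; beyond the scatter) from compound 1 to compound 3 and a 16-fold higher number (1.20 log units; beyond the scatter) from compound 2 to compound 4, 5.5-fold (0.74 log units) apart, beyond the scatter of two such steps

Among the compounds shown here, with only two pairs, this does not show which feature of the cores goes with the difference in size, nor how the change would behave on any further core, so within these compounds a step read on one core points the way on the other without fixing how large it will be.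

The compounds shown leave open whether the loss follows the bromine, the double bond or the carbonyl, since the whole group leaves at once, and a plain acetyl group or an unbrominated propenoyl group on the same nitrogen would begin to separate these. Going by these compounds, it also remains open which of the differences between the two cores matters, and a pair differing in one place only, such as the core of compound 2 with an ethoxy group added, would bear on that.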